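This account rests on a few compounds, and the source may have more. Where it says the series, first, only, none or still open, it means among the compounds named here.

Measured so far in a functional assay on MCF7 cells (Homo sapiens) for cytotoxicity, read by sulforhodamine B assay, with a stated time of 48 h; on this read-out higher numbers stand for weaker inhibition and lower numbers for stronger inhibition:
compound 1 `COc1ccc(C2C(C#N)=C(/N=C/c3ccccc3)Oc3nc(Nc4ccc(S(N)(=O)=O)cc4)sc32)cc1`: 33600 nM
compound 2 `COc1ccc(C2C(C#N)=C(/N=C/c3ccc(F)cc3)Oc3nc(Nc4ccc(S(N)(=O)=O)cc4)sc32)cc1`: 28900 nM
compound 3 `COc1ccc(C2C(C#N)=C(/N=C/c3ccc(Cl)cc3Cl)Oc3nc(Nc4ccc(S(N)(=O)=O)cc4)sc32)cc1`: 23500 nM

Compound 3 gives the smallest of the three numbers, but the steps of a 1.4-fold lower number from compound 1 to compound 3 (0.16 log units; within the scatter) and a 1.2-fold lower number from compound 2 to compound 3 (0.09 log units; within the scatter) are both within the scatter, so the three compounds cannot be separated in this assay. Compound 4 `COc1ccc(C2C(C#N)=C(/N=C/c3ccc(O)cc3)Oc3nc(Nc4ccc(S(N)(=O)=O)cc4)sc32)cc1` is not yet measured. Its change from compound 3 is 4-hydroxyphenyl in place of 2,4-dichlorophenyl on a carbon with a double bond to nitrogen. Among the compounds with values here, the steps that bear on it are those at the same carbon, a 1.4-fold lower number from compound 1 to compound 3 (0.16 log units; within the scatter) and a 1.2-fold lower number from compound 2 to compound 3 (0.09 log units; within the scatter), and also a 1.2-fold lower number from compound 1 to compound 2 (0.07 log units; within the scatter) on the same aryl ring; none passed the scatter. The expected step of a 1.1-fold higher number from compound 3 to compound 4 (0.03 log units; within the scatter) is therefore small, in no settled direction. Compound 4 is estimated at 25000 nM, with a range from 12000 nM to 50000 nM.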

Compound 4, half-maximal inhibitory concentration: 34500 nM
Estimate against measurement, compound 4: 1.4-fold (0.14 log units) below, within the range that was stated.
By their numbers in this assay, from the lowest: compounds 3, 2, 1 and 4 (each within the scatter of the next).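

In this assay, within the data shown here, the hydroxy group brings a hydrogen-bond donor onto this aryl ring, yet no step to it passes the scatter (a 1.5-fold higher number from compound 3 to compound 4 (0.17 log units; within the scatter); a 1.2-fold higher number from compound 2 to compound 4 (0.08 log units; within the scatter); a 1.0-fold higher number from compound 1 to compound 4 (0.01 log units; within the scatter)). Hydroxy thus joins hydrogen, fluoro and the 2,4-dichloro pattern as changes that cannot be separated across compound 1, compound 2, compound 3 and compound 4. No evidence on the cause of this flat result is available.

As far as these compounds go, whether an amine or a carboxylic acid on this aryl ring would move the number beyond the scatter stays open. So does the effect of a longer alkyl chain in place of the ring at this carbon.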